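Swapping the benzyl substituent in a bombesin receptor agonist series

The compounds below may be only part of what the source reports. "The series", "measured", "known", "first", "only" and "open" are said of these compounds alone.

Compound 1, `O=C(O)c1ccccc1-c1ccc(CCc2ncc(CC3CCC3)[nH]2)cc1`: 7.1 nM
Compound 2, `COc1cccc(Cc2cnc(CCc3ccc(-c4ccccc4C(=O)O)cc3)[nH]2)c1`: 79 nM
Compound 3, `O=C(O)c1ccccc1-c1ccc(CCc2ncc(Cc3ccccc3F)[nH]2)cc1`: 9.5 nM

These three compounds share a core and differ only in the group attached to a saturated chain carbon bound to an aromatic carbon. In an in vitro functional assay on cells for agonist activity at Bombesin receptor subtype-3 (Mus musculus), read by luminescence and calcium flux (a higher number here means that more compound is needed for the effect, a lower number that less compound is needed), compound 3 stands second of the three, close to compound 1 and well apart from compound 2.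

Compound 4, `Cc1cccc(Cc2cnc(CCc3ccc(-c4ccccc4C(=O)O)cc3)[nH]2)c1`, is the next variation: 3-methylphenyl in place of 2-fluorophenyl on a saturated chain carbon bound to an aromatic carbon.

For the measured compounds named here, two measured steps bear on this change. The step of an 8.3-fold lower number from compound 2 to compound 3 (0.92 log units; beyond the scatter) shows that a 3-methoxyphenyl group is weaker than 2-fluorophenyl, and an 11-fold higher number from compound 1 to compound 2 (1.05 log units; beyond the scatter) shows the same group weaker than cyclobutyl, while a 1.3-fold higher number from compound 1 to compound 3 (0.13 log units; within the scatter) is within the scatter. Compound 4 carries a 3-methylphenyl group, which again places a substituent in the 3-position rather than the 2-position, so a step toward a higher number is expected, though perhaps smaller than for compound 2.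

For compound 4 the expected step is a 3.2-fold higher number from compound 3 to compound 4 (0.50 log units; beyond the scatter), giving an estimate of 30 nM, within a range from 10 nM to 100 nM.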

Compound 4, half-maximal effective concentration: 75 nM
Compound 4: the middle estimate sits 2.5-fold (0.40 log units) below what was measured; the measured number falls inside the stated range.
By their numbers in this assay, from the lowest: compounds 1 and 3 (each within the scatter of the next); then compounds 4 and 2 (each within the scatter of the next).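

Methyl in place of methoxy gives a 1.1-fold lower number from compound 2 to compound 4 (0.02 log units; within the scatter), so the high number of compound 2 does not depend on the methoxy group alone. The 3-methylphenyl group also gives a 7.9-fold higher number from compound 3 to compound 4 (0.90 log units; beyond the scatter) and an 11-fold higher number from compound 1 to compound 4 (1.02 log units; beyond the scatter), so both 3-substituted phenyl groups shown sit well above 2-fluorophenyl and cyclobutyl. No measurement here explains this difference.

Still, 2-fluorophenyl and 3-methylphenyl differ both in the substituent and in where it sits on the phenyl ring. A 2-methylphenyl or 3-fluorophenyl group would separate those two changes.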